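Changing the Group on an Aromatic Nitrogen

The compounds below may be only part of what the source reports. "The series", "measured", "known", "first", "only" and "open" are said of these compounds alone.

Three compounds that share one core and differ only in the group attached to an aromatic nitrogen have been tested in a functional assay on HepG2 cells (Homo sapiens) for inhibition, read by MTT assay, with a stated time of 72 h; on this read-out higher numbers stand for weaker inhibition and lower numbers for stronger inhibition. Compound 1 `CCc1ccc(-n2cc(COc3cccc(NC(=O)Nc4ccc(Cl)c(C(F)(F)F)c4)c3)nn2)cc1` gives 1950 nM, which places it second highest among the three numbers, with its two neighbours very close on either side. Compound 2 `CC(C)c1ccccc1-n1cc(COc2cccc(NC(=O)Nc3ccc(Cl)c(C(F)(F)F)c3)c2)nn1` gives 1900 nM, and compound 3 `O=C(Nc1cccc(OCc2cn(-c3cccc(F)c3)nn2)c1)Nc1ccc(Cl)c(C(F)(F)F)c1` gives 2120 nM. The step of a 1.0-fold lower number from compound 1 to compound 2 (0.01 log units; within the scatter) and the step of a 1.1-fold higher number from compound 1 to compound 3 (0.04 log units; within the scatter) both stay inside the usual scatter, as does a 1.1-fold higher number from compound 2 to compound 3 (0.05 log units; within the scatter), so on this read-out none of these three groups can be told apart from the others.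

Compound 4 `O=C(Nc1cccc(OCc2cn(-c3ccccc3I)nn2)c1)Nc1ccc(Cl)c(C(F)(F)F)c1` is the next member of this set. Relative to compound 1 the difference is 2-iodophenyl in place of 4-ethylphenyl on an aromatic nitrogen. The three measured steps all concern exactly this position, and every one of them shows no movement beyond the scatter, so a step without a meaningful shift is the most reasonable expectation for compound 4, estimated as a 1.0-fold higher number from compound 1 to compound 4 (0.01 log units; within the scatter). Compound 4 is therefore expected to give about 2000 nM in this assay, with a likely range from 1000 nM to 4000 nM.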

Compound 4, half-maximal inhibitory concentration: 2870 nM
Beside the measured number, compound 4's estimate is 1.4-fold (0.16 log units) below it; the range from low to high includes it.
By their numbers in this assay, from the lowest: compounds 2, 1, 3 and 4 (each within the scatter of the next).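

In this assay, the step of a 1.5-fold higher number from compound 1 to compound 4 (0.17 log units; within the scatter) and the step of a 1.4-fold higher number from compound 3 to compound 4 (0.13 log units; within the scatter) both stay inside the scatter, as does the step of a 1.5-fold higher number from compound 2 to compound 4 (0.18 log units; within the scatter) where iodo replaces isopropyl at the same place on the phenyl ring. The earlier compounds shown here carried only carbon chains or fluoro on this ring, so the new information is that a substituent containing iodine also leaves the number indistinguishable from the rest, and all four compounds now read as one flat set. This position on the aromatic nitrogen therefore accepts 4-ethylphenyl, 2-isopropylphenyl, 3-fluorophenyl and 2-iodophenyl with no difference that this read-out can resolve, and there is no evidence here that explains why these groups read alike.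

Going by these compounds, all four groups are phenyl rings bearing a single carbon chain or halogen, so it remains open whether a phenyl ring carrying an amine or a carboxylic acid would keep the number in this range. On these data alone, it is equally open whether a plain longer alkyl chain with no ring, placed on this nitrogen, would do the same.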